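Aryl change on the amide-type nitrogen of compound 3

This account rests on a few compounds, and the source may have more. Where it says the series, first, only, none or still open, it means among the compounds named here.

In a functional assay on MDA-MB-436 cells (Homo sapiens) for antiproliferative activity, read by MTT assay, with a stated time of 48 h (a lower number here means a stronger inhibitor, a higher number a weaker inhibitor), compound 1 `C=CS(=O)(=O)N1CCN(c2ncnc3sc(-c4ccc(N5CCN(C)CC5)cc4)cc23)CC1` gives 8760 nM, compound 2 `CN1CCN(c2ccc(-c3cc4c(N5CCN(S(=O)(=O)/C=C/c6ccccc6)CC5)ncnc4s3)cc2)CC1` gives 8670 nM and compound 3 `CN1CCN(c2ccc(-c3cc4c(N5CCN(C(=O)Nc6ccc(OC(F)(F)F)cc6)CC5)ncnc4s3)cc2)CC1` gives 6250 nM. These three values lie within the scatter of one another, so compound 3 stands level with the other two. Compound 4 `CN1CCN(c2ccc(-c3cc4c(N5CCN(C(=O)Nc6ccccc6F)CC5)ncnc4s3)cc2)CC1` carries 2-fluorophenyl in place of 4-(trifluoromethoxy)phenyl on an amide-type nitrogen. Within the data shown here, the only measured step, a 1.0-fold lower number from compound 1 to compound 2 (0.00 log units; within the scatter), stays within the scatter, but it concerns a group on a sulfonyl sulfur, so no measured step covers this change directly. No shift beyond the scatter is expected in this assay. The estimated step is a 1.0-fold higher number from compound 3 to compound 4 (0.02 log units; within the scatter). For compound 4 the expected value is 6500 nM, with an estimated range of 2500 nM to 15000 nM.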

Compound 4, half-maximal inhibitory concentration: 14300 nM
Compound 4: middle estimate off by 2.2-fold (0.34 log units), on the low side; low and high end bracket the measured number.
By their numbers in this assay, from the lowest: compounds 3, 2, 1 and 4 (each within the scatter of the next, the first and the last beyond it).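

In this assay, among these compounds, the aryl group on the amide-type nitrogen gives the first single change that passes the scatter, a 2.3-fold higher number from compound 3 to compound 4 (0.36 log units; beyond the scatter) with 2-fluorophenyl in place of 4-(trifluoromethoxy)phenyl. Exchanging either sulfonyl group for (2-fluorophenyl)carbamoyl stays within the scatter, a 1.6-fold higher number from compound 2 to compound 4 (0.22 log units; within the scatter) and a 1.6-fold higher number from compound 1 to compound 4 (0.21 log units; within the scatter) so these exchanges show no comparable shift. Nothing available explains the aryl step. Open, going by these compounds, is whether the step follows the arrival of 2-fluorophenyl or the departure of 4-(trifluoromethoxy)phenyl. A plain phenyl or an aminophenyl on the same nitrogen would help separate the two.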